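Aryl swap on the carbonyl carbon: cytotoxicity notes

A few compounds are considered here, and "the series" means these few. Any claim that something is new, unique, unknown or untested is made for them only; others in the source may bear on it.

Compound 3 `COC(=O)c1cc(-c2cccc(NC(=O)c3ccc(/C=C/C(=O)c4ccc(C)cc4)cc3)c2)on1` carries a 4-methylphenyl on a carbonyl carbon. In an ADME assay on Vero cells (Chlorocebus sabaeus) for cytotoxicity, read by MTT assay, with a stated time of 72 h (a lower number here means that less compound is tolerated, a higher number that more compound is tolerated), compound 3 gives only a limit, > 80 ug/mL (the limit of > 80 ug/mL in this assay, at which 1 of the 3 values shown sits). Compound 1 `COC(=O)c1cc(-c2cccc(NC(=O)c3ccc(/C=C/C(=O)c4ccc(OC)cc4OC)cc3)c2)on1` likewise returns a limit, > 50 ug/mL (the limit of > 50 ug/mL in this assay, at which 1 of the 3 values shown sits). Compound 2 `COC(=O)c1cc(-c2cccc(NC(=O)c3ccc(/C=C/C(=O)c4ccc(Cl)cc4Cl)cc3)c2)on1` also returns a limit, > 40 ug/mL (the limit of > 40 ug/mL in this assay, at which 1 of the 3 values shown sits). The steps a step that the two limits leave unreadable from compound 1 to compound 3, a step that the two limits leave unreadable from compound 2 to compound 3 and a step that the two limits leave unreadable from compound 1 to compound 2 are all unreadable; none of the three aryl groups on the carbonyl carbon reached a measurable half-maximal cytotoxic concentration. Compound 4 `COC(=O)c1cc(-c2cccc(NC(=O)c3ccc(/C=C/C(=O)c4cccc(F)c4)cc3)c2)on1` differs from compound 3 as follows: 3-fluorophenyl in place of 4-methylphenyl on a carbonyl carbon. For the measured compounds named here, with every measured step unreadable, no size can be taken from the earlier steps. Compound 4 is then expected to stand near the same limit, 80 ug/mL (40 ug/mL to 160 ug/mL). The step of a number no higher from compound 3 to compound 4 (the limit leaves the size open) is expected to be none beyond the scatter.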

Compound 4, half-maximal cytotoxic concentration: > 40 ug/mL
Compound 4: a limit, no number; the forecaster's own chance of this, stated with the estimate: 85%; the middle value is on the limit's open side.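

Compound 4 also returns only a limit, > 40 ug/mL, so its steps from compound 1, compound 2 and compound 3 cannot be read. The compounds shown leave open where any actual half-maximal cytotoxic concentration lies in this assay, and whether the aryl group on the carbonyl carbon affects it.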